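Phenylsulfonyl for chlorobenzoyl on the amine nitrogen

A few compounds are considered here, and "the series" means these few. Any claim that something is new, unique, unknown or untested is made for them only; others in the source may bear on it.

Compound 2 `O=C(NCCNc1nccc(-c2c(-c3cccc(F)c3)nc3sccn23)n1)c1ccc(Cl)cc1` gives 8160 nM in a functional assay on SK-MEL-28 cells (Homo sapiens) for cytotoxicity, read by MTT assay (a lower number here means a stronger inhibitor, a higher number a weaker inhibitor), the smallest of the three numbers shown, although neither gap to the others exceeds the scatter. Compound 3 `O=S(=O)(NCCNc1nccc(-c2c(-c3cccc(F)c3)nc3sccn23)n1)c1ccc(C(F)(F)F)cc1` gives 8450 nM in this assay, and compound 1 `O=S(=O)(NCCCNc1nccc(-c2c(-c3cccc(F)c3)nc3sccn23)n1)c1cccc(F)c1` gives 8550 nM. Among the measured compounds shown here, the one recorded step, a 1.0-fold lower number from compound 1 to compound 2 (0.02 log units; within the scatter), moves nothing beyond the scatter. Compound 4 `O=S(=O)(NCCNc1nccc(-c2c(-c3cccc(F)c3)nc3sccn23)n1)c1ccccc1` carries the change (phenylsulfonyl in place of (4-chlorophenyl)carbonyl on an amine nitrogen). Because compound 3 gives 8450 nM with a sulfonyl on the same chain, no shift beyond the scatter is expected for compound 4, an expected step of a 1.0-fold higher number from compound 2 to compound 4 (0.02 log units; within the scatter). Compound 4 is therefore estimated at 8500 nM, with a range from 4000 nM to 18000 nM.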

Compound 4, half-maximal inhibitory concentration: 19000 nM
Beside the measured number, compound 4's estimate is 2.2-fold (0.35 log units) below it, outside the stated range (above it).
By their numbers in this assay, from the lowest: compounds 2, 3 and 1 (each within the scatter of the next); then compound 4.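

In this assay, among the compounds shown here, phenylsulfonyl on the amine nitrogen gives the first step beyond the scatter, a 2.3-fold higher number from compound 2 to compound 4 (0.37 log units; beyond the scatter). A sulfonyl group alone does not set this result apart: with the sulfonyl retained, hydrogen in place of trifluoromethyl on an aromatic carbon gives a 2.2-fold higher number from compound 3 to compound 4 (0.35 log units; beyond the scatter). The step of a 2.2-fold higher number from compound 1 to compound 4 (0.35 log units; beyond the scatter) runs the same way, leaving the unsubstituted phenyl ring alone at the high end of the four numbers.

Nothing shown bears on the reason for these steps. As far as these compounds go, whether a plain benzoyl on the same chain, or a methoxy group on the phenylsulfonyl ring, would fall with compound 4 or with compound 2 stays open.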